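The compounds below may be only part of what the source reports. "The series", "measured", "known", "first", "only" and "open" are said of these compounds alone.

Measured compounds:
- compound 1, `Cc1cccc(N2CCN(C(=O)CN3C(=O)CC(C)(c4ccccc4)C3=O)CC2)c1`: 100 mg/kg
- compound 2, `COc1cccc(N2CCN(C(=O)CN3C(=O)CC(C)(c4ccccc4)C3=O)CC2)c1`: "not active" (no number reported)
- compound 3, `CC1(c2ccccc2)CC(=O)N(CC(=O)N2CCN(c3ccccc3)CC2)C1=O`: 300 mg/kg

In a functional assay on the whole organism (strain CD-1) with Mus musculus as the target, in the maximal electroshock model, with a stated time of 0.5 h (on this read-out lower numbers stand for an effect already at smaller amounts and higher numbers for an effect only at larger amounts of compound), compound 3 stands as the higher of the two reported numbers; compound 1 is its nearest neighbour, and a 3.0-fold higher number from compound 1 to compound 3 (0.48 log units; beyond the scatter). Compound 2 gave no number at all in this assay, so it cannot be ranked.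

Compound 4, `COc1ccccc1N1CCN(C(=O)CN2C(=O)CC(C)(c3ccccc3)C2=O)CC1`, differs from compound 3 in one place: methoxy in place of hydrogen on an aromatic carbon. For the measured compounds named here, only one measured step bears on this: a 3.0-fold higher number from compound 1 to compound 3 (0.48 log units; beyond the scatter) shows that a small group on that same aromatic ring changed the number by a modest amount. The methoxy group also appears in compound 2, though at a different place on the ring, and there compound 2 was reported inactive. Taken together, the step is expected to be small or not beyond the scatter, with some risk that the assay again reports no number. For compound 4 the estimate is 300 mg/kg with a range from 100 mg/kg to 600 mg/kg, which means no change at the digits printed from compound 3 to compound 4 (within the scatter) is expected.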

Compound 4, minimum effective dose: 100 mg/kg
Compound 4: the middle estimate sits 3.0-fold (0.48 log units) above what was measured, within the range that was stated.
By their numbers in this assay, from the lowest: compounds 1 and 4 (each within the scatter of the next); then compound 3.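

In this assay, methoxy on the aromatic carbon ortho to a large group gives a 3.0-fold lower number from compound 3 to compound 4 (0.48 log units; beyond the scatter), so a group at this place can bring the effective dose down. Two different substituted rings can also serve equally well: exchanging 3-methylphenyl for 2-methoxyphenyl gives no change at the digits printed from compound 1 to compound 4 (within the scatter) and the two compounds cannot be told apart. Compound 2 carries methoxy at another place on the ring and was reported without a number, whereas compound 4 has one, so for this group the place on the ring makes a visible difference.

Nothing shown gives a reason for these steps. Still open, as far as these compounds go, is whether an amine, a carboxylic acid or a longer chain at this same aromatic carbon would keep the effect of methoxy or lose it.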